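The compounds below may be only part of what the source reports. "The series", "measured", "known", "first", "only" and "open" are said of these compounds alone.

Three compounds built on a shared core, differing only in the group carried on an amide-type nitrogen, have been measured in a functional assay on the whole organism (strain Wistar) for inhibition, with Rattus norvegicus as the target, read by paw edema, with stated times of 30 min and 2 h, at a dose of 20 mg/kg; a lower number here means less inhibition, a higher number more inhibition at the dose given (going by the name of the read-out). Compound 1 `CCOC(=O)C1=C(C)NC(C)=C(C(=O)OCC)C1c1ccc(OCC(=O)Nc2nc3ccccc3s2)cc1` gives 64.5%. Compound 2 `CCOC(=O)C1=C(C)NC(C)=C(C(=O)OCC)C1c1ccc(OCC(=O)NNC(=O)c2sccc2Cl)cc1` gives 57.2%. Compound 3 `CCOC(=O)C1=C(C)NC(C)=C(C(=O)OCC)C1c1ccc(OCC(=O)NNC(=O)CCC(=O)O)cc1` gives 57.8%, the second highest of the three numbers; the nearest of the other numbers is reached by a number 0.6 percentage points higher from compound 2 to compound 3 (within the scatter), the furthest by a number 6.7 percentage points lower from compound 1 to compound 3 (within the scatter). The remaining comparison, a number 7.3 percentage points lower from compound 1 to compound 2 (within the scatter), completes the picture: none of the three steps leaves the scatter, so no ordering among the three measured compounds can be claimed.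

Compound 4 `CCOC(=O)C1=C(C)NC(C)=C(C(=O)OCC)C1c1ccc(OCC(=O)NN2C(=O)c3ccccc3C2=O)cc1` continues from compound 3 by a group of 11 heavy atoms (8 carbon, 1 nitrogen, 2 oxygen; one five-membered non-aromatic ring with 1 hetero atom, one six-membered aromatic ring of carbon only) in place of a group of 8 heavy atoms (4 carbon, 1 nitrogen, 3 oxygen; no ring), on an amide-type nitrogen. For the measured compounds named here, no measured pair exchanges groups of this kind, so the only guidance comes from the three steps already seen, each of which replaces one group on the same amide-type nitrogen and each of which stays within the scatter. On that basis the step is expected to be a number 0.2 percentage points higher from compound 3 to compound 4 (within the scatter), a change that would not rise above the scatter. Compound 4 is therefore estimated to give 58% in this assay, with an expected range from 47% to 69%.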

Compound 4, a percentage reported as inhibition, in the whole organism at one dose (the size of the read-out at that dose, not a potency): 57.2%
For compound 4 the middle estimate is 0.8 percentage points above the measured one, within the range that was stated.
By their numbers in this assay, from the lowest: compounds 2, 4, 3 and 1 (each within the scatter of the next).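

On the amide-type nitrogen, the group with one five-membered non-aromatic ring and one six-membered aromatic ring takes the place of ((2-carboxyethyl)carbonyl)amino in this assay with a number 0.6 percentage points lower from compound 3 to compound 4 (within the scatter), and the comparisons with the other two compounds give no change at the digits printed from compound 2 to compound 4 (within the scatter) and a number 7.3 percentage points lower from compound 1 to compound 4 (within the scatter). The earlier compounds shown here carried either no ring or only aromatic rings in this place, so compound 4 extends the series to a non-aromatic ring, and with 0 hydrogen-bond donors in the entering group against 2 in the group leaving, all four compounds still lie within the scatter of one another in this assay. Nothing measured here explains this outcome.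

As far as these compounds go, whether any group on this nitrogen can move the number in this assay beyond the scatter remains open, for instance a free amine or a longer alkyl chain. The compounds shown also leave open how the inhibition depends on dose, since each number comes from a single dose and says nothing about potency.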